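A Cycloheptyl Swap Carried from One Core to Another

The source may hold more compounds than are shown below. What is called first, only, known or untested is meant among the compounds shown, and "the series" means these compounds.

Three compounds have been measured in a functional assay on MCF7 cells (Homo sapiens) for cytotoxicity, read by WST assay, with a stated time of 72 h; a lower number here means a stronger inhibitor, a higher number a weaker inhibitor:
compound 1, `O=C1Nc2c(ccc(F)c2F)C1(c1ccc(O)cc1)c1ccc(F)cc1`, gives 2.6 nM;
compound 2, `O=C1Nc2c(ccc(F)c2F)C1(c1ccc(O)cc1)C1CCCCCC1`, gives 1.2 nM;
compound 3, `Cc1cc(C)c2c(c1)C(c1ccc(O)cc1)(c1ccc(F)cc1)C(=O)N2`, gives 40 nM.

Compound 1 and compound 2 share a core and differ in one place: cycloheptyl in place of 4-fluorophenyl on a saturated ring carbon. That change produced a 2.2-fold lower number from compound 1 to compound 2 (0.34 log units; beyond the scatter). Compound 3 carries a different core; how its core differs from that of compound 1 is not broken down here. In this assay compound 3 gives the highest of the three numbers, lying beyond the scatter above both compound 1 and compound 2.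

Compound 4, `Cc1cc(C)c2c(c1)C(c1ccc(O)cc1)(C1CCCCCC1)C(=O)N2`, has not yet been measured in this assay. It relates to compound 3 exactly as compound 2 relates to compound 1: cycloheptyl in place of 4-fluorophenyl on a saturated ring carbon. The place is described in the same words in both cases, so this is the same change, now made on the core of compound 3. Among the measured compounds shown here, the step is expected to be a 2.2-fold lower number from compound 3 to compound 4 (0.35 log units; beyond the scatter), resting on the single earlier instance a 2.2-fold lower number from compound 1 to compound 2 (0.34 log units; beyond the scatter), since the core of compound 3 has not yet seen this change. Compound 4 is therefore estimated at 18 nM, between 8 nM and 40 nM.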

Compound 4, half-maximal inhibitory concentration: > 1000 nM
Compound 4: a limit, no number; the forecaster's own chance of this, stated with the estimate: 0%; middle value at least 55-fold (1.74 log units) from the limit.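

In this assay compound 4 gives > 1000 nM, which is a limit of the assay and not a number. Among the compounds shown here, the step is an at least 25-fold higher number from compound 3 to compound 4 (1.39 log units; beyond the scatter), so the swap of 4-fluorophenyl for cycloheptyl did not carry from the core of compound 1 to the core of compound 3, and its outcome depended on the core that bore it: the same change on two cores in this assay, a 2.2-fold lower number (0.34 log units; beyond the scatter) from compound 1 to compound 2 and an at least 25-fold higher number (1.39 log units; beyond the scatter) from compound 3 to compound 4, at least 54-fold (1.73 log units) apart, beyond the scatter of two such steps With only two cores compared, this sets no rule for other cores, and it shows neither which difference between the two cores separates the steps nor how large the second step really is, since one end of it is a limit.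

The compounds shown leave open whether the sharp rise on the core of compound 3 is particular to cycloheptyl or would also follow a smaller ring such as cyclopentyl, or an open butyl chain, in the same place. They also leave open how any such group would behave on the core of compound 1.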